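The source may report more compounds than this note shows. Statements on the series, on what has been measured and on what is new or still open speak of the compounds shown alone.

Measured in a toxicity assay on THP-1 cells (Homo sapiens) for inhibition; a lower number here means that less compound is tolerated, a higher number that more compound is tolerated:
Compound 1 `COc1ccc(-c2cnc(NC(=O)c3ncc[nH]3)n2C)cc1`: > 100000 nM
Compound 2 `COc1ccc(-c2cnc(NC(=O)c3cccc(C#N)c3)n2C)cc1`: > 100000 nM
Compound 3 `COc1ccc(-c2cnc(NC(=O)C3CCCC3)n2C)cc1`: > 100000 nM

Each entry is a limit of the assay, not a number. Compound 3 has only the limit > 100000 nM, so it cannot be ranked against the other two, which share (the limit of > 100000 nM in this assay, at which 3 of the 3 values shown sit).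

Compound 4 `COc1ccc(-c2cnc(NC(=O)c3ccc(C#N)cc3)n2C)cc1` differs from compound 3 by 4-cyanophenyl in place of cyclopentyl on a carbonyl carbon. The closest measured change is a step that the two limits leave unreadable from compound 2 to compound 3, where cyclopentyl replaces 3-cyanophenyl. Another is a step that the two limits leave unreadable from compound 1 to compound 3. Neither has a readable size, but compound 2 and compound 3 both stay at the limit of > 100000 nM in this assay, at which 3 of the 3 values shown sit, so no step beyond the scatter is expected, in either direction. The expected result is a number no higher from compound 3 to compound 4 (the limit leaves the size open). The assay will probably report only a limit again. Compound 4 is estimated at 100000 nM, with an expected range of 50000 nM to 200000 nM.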

Compound 4, half-maximal cytotoxic concentration: > 100000 nM
Compound 4 gave a limit, no number; the forecaster's own chance of this, stated with the estimate: 90%; the middle value sits exactly at the limit.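

For the compounds shown here, compound 4 also returns only a limit, so no step between it and compound 1, compound 2 or compound 3 can be read: the limit of > 100000 nM in this assay, at which 4 of the 4 values shown sit. The compounds shown leave open at what concentration any of them becomes toxic to these cells, and whether the groups on the carbonyl carbon differ in this.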